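The compounds below may be only part of what the source reports. "The series", "measured", "known", "first", "only" and "open" are said of these compounds alone.

Going by the values given here, in a physicochemical assay for solubility, read by HPLC, at pH 7.4 (a higher number here means a more soluble compound, a lower number a less soluble compound), compound 2 (`CCOCCCCc1cc(=O)c2cc([N+](=O)[O-])ccc2[nH]1`) gives 50000 nM, the only number so far. Compound 1 (`CCCCCCCc1cc(=O)c2cc([N+](=O)[O-])ccc2[nH]1`) gives < 5000 nM, which is a limit and not a number. Among the compounds with values here, the one measured step, an at least 10-fold higher number from compound 1 to compound 2 (1.00 log units; beyond the scatter), is a change on the chain, so it bears only loosely on the next change, though it shows that a single change can move the read-out beyond the scatter. Compound 3 (`CCOCCCCc1[nH]c2ccc([N+](=O)[O-])cc2c(=O)c1C(=O)OCC`) keeps the 4-ethoxybutyl group of compound 2 and differs on the core: ethoxycarbonyl in place of hydrogen on an aromatic carbon. Within the data shown here, no measured step covers a change at this aromatic carbon, so the size rests on judgement. A modest step towards a lower number in this assay is expected, and a result within the scatter remains possible. The expected step is a 3.3-fold lower number from compound 2 to compound 3 (0.52 log units; beyond the scatter). Compound 3 is estimated at 15000 nM, with an expected range of 5000 nM to 60000 nM.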

Compound 3, solubility: 5000 nM
Estimate against measurement, compound 3: 3.0-fold (0.48 log units) above; the measured number falls inside the stated range.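

In this assay, the aromatic carbon ortho to the 4-ethoxybutyl group now has a measured step of its own: ethoxycarbonyl in place of hydrogen gives a 10-fold lower number from compound 2 to compound 3 (1.00 log units; beyond the scatter). The read-out therefore moves beyond the scatter with a change on the core as well as with a change on the chain, and in the opposite direction to an at least 10-fold higher number from compound 1 to compound 2 (1.00 log units; beyond the scatter). That chain step starts from a limit and not a number, and the low end of the read-out matters for any further change in this series: the limit of < 5000 nM in this assay, at which 1 of the 3 values shown sits.

Going by these compounds, whether the step belongs to ethoxycarbonyl itself or would also appear with a carboxylic acid, an amide or a nitrile on this carbon remains open. Also open, on these data alone, is how the same change reads with a longer chain in place of the 4-ethoxybutyl group.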